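From isopropylcarbonyl to propanoyl on the shared core

The source may report more compounds than this note shows. Statements on the series, on what has been measured and on what is new or still open speak of the compounds shown alone.

Measured in a functional assay on MCF7 cells (Homo sapiens) for inhibition, read by MTT assay, with a stated time of 96 h; a higher number here means a weaker inhibitor of growth, a lower number a stronger inhibitor of growth:
- compound 1 `CC(C)C(=O)SCCCCCCNC(=O)c1cc(-c2ccncc2)n[nH]1` gives 15200 nM
- compound 2 `O=C(NCCCCCCS)c1cc(-c2ccc(-c3ccccc3)cc2)n[nH]1` gives > 50000 nM
- compound 3 `O=C(NCCCCCCS)c1cc(-c2ccc3ccccc3c2)n[nH]1` gives > 50000 nM

Going by the values given here, compound 1 holds the only actual number in this set, at 15200 nM. Compound 2 stands at > 50000 nM, which is a limit of the assay. Compound 3 gives > 50000 nM, also a limit. Compound 4 `CCC(=O)SCCCCCCNC(=O)c1cc(-c2ccncc2)n[nH]1` has not yet been measured in this assay. It differs from compound 1 by hydrogen in place of methyl on a saturated chain carbon bound to a carbonyl carbon and a saturated chain carbon, that is, isopropylcarbonyl to propanoyl. Among the compounds with values here, no measured pair shows this change. The expected 1.0-fold lower number from compound 1 to compound 4 (0.01 log units; within the scatter) is none beyond the scatter, with neither direction favoured. For compound 4 the estimated value is 15000 nM, with an expected range of 6000 nM to 38000 nM.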

Compound 4, concentration for 50% growth inhibition: > 50000 nM
Compound 4: no number, only a limit (the forecaster's own chance of this, stated with the estimate: 10%); middle value at least 3.3-fold (0.52 log units) away from the limit.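

In this assay, the change from isopropylcarbonyl to propanoyl gives an at least 3.2-fold higher number from compound 1 to compound 4 (0.51 log units; beyond the scatter), so the methyl on this saturated chain carbon cannot be lost without a step beyond the scatter. Compound 4 gives > 50000 nM, a limit of the assay and not a number. The step therefore has a minimum size only, and compound 1 remains the sole measured number: the limit of > 50000 nM in this assay, at which 3 of the 4 values shown sit.

Going by these compounds, whether a longer chain or an amine at this carbon would give a measurable number remains open. On these data alone, the full size of the step also remains open.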